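Shifting a Methoxy Group on the Diaryl Ether

The source may report more compounds than this note shows. Statements on the series, on what has been measured and on what is new or still open speak of the compounds shown alone.

Three compounds share one core and differ only in the aryl group on an oxygen on an aromatic ring. Compound 1 `Cc1cn(C2CCN(Cc3cccc(Oc4cc(F)cc(F)c4)c3)CC2)c(=O)[nH]c1=O` carries a 3,5-difluorophenyl there; in an ADME assay on MRC5 cells (Homo sapiens) for cytotoxicity, read by fluorescence and resazurin assay, with a stated time of 3 days (on this read-out lower numbers stand for stronger inhibition and higher numbers for weaker inhibition), compound 1 returns only the limit > 64000 nM, not a number. Compound 2 `Cc1cn(C2CCN(Cc3cccc(Oc4cccc(C(F)(F)F)c4)c3)CC2)c(=O)[nH]c1=O` carries a 3-(trifluoromethyl)phenyl and gives 12400 nM. Compound 3 `COc1ccc(Oc2cccc(CN3CCC(n4cc(C)c(=O)[nH]c4=O)CC3)c2)cc1` carries a 4-methoxyphenyl and gives 28000 nM, the highest of the two numbers; its nearest neighbour is told by a 2.3-fold higher number from compound 2 to compound 3 (0.35 log units; beyond the scatter). The step of an at least 2.2-fold lower number from compound 1 to compound 3 (0.35 log units; beyond the scatter) rests on a limit of > 64000 nM in this assay, at which 1 of the 3 values shown sits, and can only be read as a bound.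

Compound 4 `COc1cccc(Oc2cccc(CN3CCC(n4cc(C)c(=O)[nH]c4=O)CC3)c2)c1` is the next step: 3-methoxyphenyl in place of 4-methoxyphenyl on an oxygen on an aromatic ring. Within the data shown here, no measured step moves a methoxy group from one position to another; the steps of an at least 5.1-fold lower number from compound 1 to compound 2 (0.71 log units; beyond the scatter), an at least 2.2-fold lower number from compound 1 to compound 3 (0.35 log units; beyond the scatter) and a 2.3-fold higher number from compound 2 to compound 3 (0.35 log units; beyond the scatter) exchange one aryl for another of different composition, and all of them stay modest. With the same atoms joined differently, a smaller step is expected in this assay, with no clear direction. The estimated step of no change at the digits printed from compound 3 to compound 4 (within the scatter) is expected to remain within the scatter. Compound 4 is therefore estimated at 28000 nM, within 12000 nM to 64000 nM.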

Compound 4, half-maximal inhibitory concentration: 25300 nM
For compound 4 the middle estimate is 1.1-fold (0.04 log units) above the measured one, and the stated range covers the measured number.
By their numbers in this assay, from the lowest: compound 2; then compounds 4 and 3 (each within the scatter of the next). At a limit, above all of these: compound 1.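

Moving the methoxy group from the 4-methoxyphenyl to the 3-methoxyphenyl is the first change here that leaves the composition of the aryl group untouched, and in this assay it gives a 1.1-fold lower number from compound 3 to compound 4 (0.04 log units; within the scatter), so the two placements cannot be told apart. The exchange of methoxy for trifluoromethyl on an aromatic carbon, with the placement of the group kept, gives a 2.0-fold higher number from compound 2 to compound 4 (0.31 log units; beyond the scatter), a modest step beyond the scatter that is close in size to the earlier 2.3-fold higher number from compound 2 to compound 3 (0.35 log units; beyond the scatter), which also changed the placement, so compound 2 stays apart from both methoxy compounds. Compound 1 has a limit and not a number, so the step of an at least 2.5-fold lower number from compound 1 to compound 4 (0.40 log units; beyond the scatter) can be read only as a bound: the limit of > 64000 nM in this assay, at which 1 of the 4 values shown sits.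

The compounds shown leave open whether placement would matter as little for a group other than methoxy on this aryl ring, such as an amine or a carboxylic acid. They also leave open whether moving the trifluoromethyl would be as silent as moving the methoxy, and how any of these aryl groups would read on a changed core.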